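Removing One Methoxy from an Inactive Benzothiazole Hydrazone

A few compounds are considered here, and "the series" means these few. Any claim that something is new, unique, unknown or untested is made for them only; others in the source may bear on it.

Measured compounds:
compound 1 `O=C(N/N=C/c1ccccc1O)c1ccc(-c2nc3ccccc3s2)cc1`: 5550 nM
compound 2 `COc1ccc(/C=N/NC(=O)c2ccc(-c3nc4ccccc4s3)cc2)cc1OC`: "not active" (no number reported)

Of the compounds shown here, two sharing the same core have been tested in an assay on isolated protein for inhibition of Maltase-glucoamylase (Homo sapiens), with a stated time of 15 min; on this read-out lower numbers stand for stronger inhibition and higher numbers for weaker inhibition. Compound 1 `O=C(N/N=C/c1ccccc1O)c1ccc(-c2nc3ccccc3s2)cc1` gives 5550 nM. Compound 2 `COc1ccc(/C=N/NC(=O)c2ccc(-c3nc4ccccc4s3)cc2)cc1OC` was reported as "not active" (no number reported), so no single number is available for it and its place on the scale cannot be stated more closely than that it showed no measurable inhibition.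

Compound 3 `COc1ccc(/C=N/NC(=O)c2ccc(-c3nc4ccccc4s3)cc2)cc1` has not yet been measured in this assay. It differs from compound 2 in one place: hydrogen in place of methoxy on an aromatic carbon. The structures of compounds 2 and 3 are not connected by any measured step, so the size of the change cannot be read from the data. Given that compound 2 showed no activity, a step from compound 2 toward compound 3 is expected to be small or none beyond the scatter, with the possibility that the read-out again reports no number.

Compound 3 is estimated at 20000 nM, within a range of 5000 nM to 80000 nM.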

Compound 3, half-maximal inhibitory concentration: 18300 nM
Compound 3: the middle estimate sits 1.1-fold (0.04 log units) above what was measured; measured number inside the range.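

Removing the methoxy, which turns the 3,4-dimethoxyphenyl of compound 2 into the 4-methoxyphenyl of compound 3, yields a measurable number in this assay: compound 3 gives 18300 nM, while compound 2 was reported as not active, so the size of this step cannot be read. Within the data shown here, the result shows only that a compound with hydrogen on this aromatic carbon gives a number on this read-out, and it also makes a second comparison possible, with 4-methoxyphenyl in place of 2-hydroxyphenyl on the carbon with a double bond to nitrogen, which brings a 3.3-fold higher number from compound 1 to compound 3 (0.52 log units; beyond the scatter). Nothing measured here accounts for either difference.

The compounds shown leave open what a hydroxyl, an amine or a fluorine on the aromatic carbon that lost the methoxy would do to the read-out in this assay. They also do not settle whether the remaining methoxy contributes to the number for compound 3, since a plain phenyl or a 4-hydroxyphenyl in its place is not among them.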